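Three Inactive Analogues and a Fourth Awaiting Measurement

The source may report more compounds than this note shows. Statements on the series, on what has been measured and on what is new or still open speak of the compounds shown alone.

Compound 1 `COc1cc(OC)c2c(=O)cc(/C=C/c3ccccc3)oc2c1`, compound 2 `COc1cccc2oc(/C=C/c3ccc(OC(F)(F)F)cc3)cc(=O)c12` and compound 3 `COc1ccc(/C=C/c2cc(=O)c3c(OC)cc(OC)cc3o2)cc1` were tested in a functional assay on PC-3 cells (Homo sapiens) for antiproliferative activity, read by MTT assay, with a stated time of 12 h; a lower number here means a stronger inhibitor, a higher number a weaker inhibitor. In this assay compound 1 gives > 40000 nM, a limit of the assay rather than a number. Compound 2 likewise gives only a limit, > 40000 nM. Compound 3 gives > 40000 nM, again a limit. One change separates two of them, (hydrogen in place of methoxy on an aromatic carbon), and its step that the two limits leave unreadable from compound 3 to compound 1 cannot be read because of the limit of > 40000 nM in this assay, at which 3 of the 3 values shown sit. The cores of compound 2 and compound 3 differ in a way not broken down here. Compound 4 `O=c1cc(/C=C/c2ccc(OC(F)(F)F)cc2)oc2ccccc12` is not yet measured; it arises from compound 2 through the same kind of change, (hydrogen in place of methoxy on an aromatic carbon), though here the place is part of a fused or bridged system of two rings, ortho to a fused ring and meta to a fused ring, rather than para to a large group. Since compound 2 sits at the limit of > 40000 nM in this assay, at which 3 of the 3 values shown sit, the expected step is a step that the limit leaves unreadable from compound 2 to compound 4. Compound 4 is therefore estimated at about 60000 nM.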

Compound 4, half-maximal inhibitory concentration: 28900 nM
Estimate against measurement, compound 4: 2.1-fold (0.32 log units) above, and the stated range covers the measured number.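

In this assay putting hydrogen in place of methoxy on an aromatic carbon gives a small readable step (an at least 1.3-fold lower number from compound 2 to compound 4 (0.14 log units; that floor lies within the scatter)) . Compound 2 has only a limit, so the true step could be larger, but this floor alone shows no change beyond the usual scatter. The same kind of change on the other core, at a different place, cannot be read, so nothing shows whether the step carries from one core to the other, because both of its compounds stand at a limit: (the limit of > 40000 nM in this assay, at which 3 of the 4 values shown sit) .

On these data alone, it remains open how an amine or a carboxylic acid at that aromatic carbon would compare with compound 4, at 28900 nM in the same assay. Also open, as far as these compounds go, is whether any change on these cores gives a step clearly beyond the scatter.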